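This account rests on a few compounds, and the source may have more. Where it says the series, first, only, none or still open, it means among the compounds named here.

Measured so far:
compound 1 `Cc1sc(N)c(C(=O)c2cccc3ccccc23)c1C` gives 18% in an assay on isolated protein with adenosine receptor A3 (Homo sapiens) as the target, tested at 10 uM; on this read-out lower numbers stand for less inhibition and higher numbers for more inhibition at the one concentration tested (going by the name of the read-out);
compound 2 `COc1ccc(C(=O)c2c(N)sc3c2CCC3)c2ccccc12` gives 57%;
compound 3 `Nc1sc2c(c1C(=O)c1cccc3ccccc13)CCCC2` gives 34.5%.

Among these three numbers compound 3 stands second highest: compound 1 sits lower, beyond the scatter, and compound 2 sits higher, also beyond the scatter. Compound 4 `Nc1sc2c(c1C(=O)c1ccc(I)c3ccccc13)CCCC2` has not yet been measured. It differs from compound 3 in one place: iodo in place of hydrogen on an aromatic carbon. Among the compounds with values here, no step between two measured compounds shows what this kind of change does, so the expectation rests on compound 3 alone, and the step of a number 10.5 percentage points higher from compound 3 to compound 4 (beyond the scatter) is expected to be modest, slightly upward. For compound 4 the estimated value is 45%, within a range from 20% to 70%.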

Compound 4, a percentage reported as inhibition, at one concentration (the size of the read-out at that concentration, not a potency): 48%
For compound 4 the middle estimate is 3 percentage points below the measured one; low and high end bracket the measured number.
By their numbers in this assay, from the lowest: compound 1; then compound 3; then compounds 4 and 2 (each within the scatter of the next).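

In this assay, within the data shown here, iodo in place of hydrogen on an aromatic carbon, para to a large group, gives a number 13.5 percentage points higher from compound 3 to compound 4 (beyond the scatter), the first direct reading of a single change in this set. This position therefore carries iodo with no loss of inhibition at the one concentration tested. Nothing available explains the rise.

As far as these compounds go, whether the rise is specific to iodo remains open, since chloro, bromo or an amine at this carbon could give a different number. A single pair also cannot show whether the same change would raise the number on another core.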